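The source may hold more compounds than are shown below. What is called first, only, known or untested is meant among the compounds shown, and "the series" means these compounds.

Compound 1 `NCCCC(NC(=O)c1ccc(NCc2ccc3nc(N)nc(O)c3c2C(F)(F)F)cc1)C(=O)O` in an assay (Sus scrofa) for inhibition of Folylpolyglutamate synthase, mitochondrial (Homo sapiens); on this read-out higher numbers stand for weaker inhibition and lower numbers for stronger inhibition: 8.8 nM
Compound 2 `NCCCC(NC(=O)c1ccc(CNc2ccc3nc(N)nc(O)c3c2C(F)(F)F)cc1)C(=O)O` in this assay: 11 nM
Compound 3 `NCCCC(NC(=O)c1ccc(CNc2ccc3nc(N)nc(O)c3c2Cl)cc1)C(=O)O` in this assay: 500 nM

Compound 3 shows the highest number of the three, which here means the weakest inhibition. Compound 4 `NCCCC(NC(=O)c1ccc(CNc2ccc3nc(N)nc(O)c3c2F)cc1)C(=O)O` differs from compound 3 by fluoro in place of chloro on an aromatic carbon. Within the data shown here, the only measured step at this position is a 45-fold higher number from compound 2 to compound 3 (1.66 log units; beyond the scatter), so a change of the group on this aromatic carbon can move the number a great deal. Among the measured compounds shown here, no measured compound carries a fluoro there, so the direction for compound 4 rests on a single step and is uncertain. Compound 4 is expected to give a somewhat higher number than compound 3, about a 2.4-fold higher number from compound 3 to compound 4 (0.38 log units; beyond the scatter). The estimate for compound 4 in this assay is 1200 nM, within a range from 250 nM to 6000 nM.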

Compound 4, inhibition constant: 900 nM
Beside the measured number, compound 4's estimate is 1.3-fold (0.12 log units) above it; the range from low to high includes it.
By their numbers in this assay, from the lowest: compounds 1 and 2 (each within the scatter of the next); then compounds 3 and 4 (each within the scatter of the next).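

In this assay the change from chloro to fluoro on this aromatic carbon gives a 1.8-fold higher number from compound 3 to compound 4 (0.26 log units; within the scatter) and so leaves the two halogens indistinguishable here. Replacing trifluoromethyl with fluoro gives an 82-fold higher number from compound 2 to compound 4 (1.91 log units; beyond the scatter) and so shows that the large loss of inhibition at this position is not peculiar to chloro. Nothing available explains why trifluoromethyl stands so far apart from both halogens. Open, going by these compounds, is how a methyl group, a methoxy group, a nitrile or plain hydrogen on this carbon would compare.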